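This account rests on a few compounds, and the source may have more. Where it says the series, first, only, none or still open, it means among the compounds named here.

The compounds measured so far:
compound 1 `Cc1ccc(OCC(=O)N(Cc2cccs2)CC(C)C)cc1`: 900 nM
compound 2 `CCN(Cc1cccs1)C(=O)C[C@@H](O)c1ccccc1`: "not active" (no number reported)
compound 3 `CCN(Cc1cccs1)C(=O)COc1ccc(C(C)C)cc1`: 397 nM

In an assay on HEK293 cells for agonist activity at transient receptor potential cation channel subfamily M member 8 (Homo sapiens), read by fluorescence and calcium flux, with a stated time of 15 min (a higher number here means that more compound is needed for the effect, a lower number that less compound is needed), compound 1 gives 900 nM, the higher of the two numbers reported. Compound 3 gives 397 nM, and the gap between these two lies beyond the usual scatter. Compound 2 is reported as "not active" (no number reported), with no number given. Compound 4 `Cc1ccc(OCC(=O)N(Cc2cccs2)C(C)(C)C)cc1` has not yet been tested. It differs from compound 1 in one place: tert-butyl in place of isobutyl on an amide-type nitrogen. For the measured compounds named here, no measured pair shows what this kind of change does, so there is no step to lean on. The expectation for compound 4 is a step of a 1.3-fold higher number from compound 1 to compound 4 (0.12 log units; within the scatter) in this assay, close to the scatter, and an estimated value of 1200 nM, most likely between 400 nM and 3600 nM.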

Compound 4, half-maximal effective concentration: 11000 nM
Compound 4: the middle estimate sits 9.2-fold (0.96 log units) below what was measured, outside the stated range (above it).
By their numbers in this assay, from the lowest: compound 3; then compound 1; then compound 4.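

Replacing isobutyl with tert-butyl on the amide-type nitrogen leaves the count at four carbons, yet in this assay the result is a large step (a 12-fold higher number from compound 1 to compound 4 (1.09 log units; beyond the scatter)) and far more compound is needed for the effect. This position therefore responds strongly to how the same carbon atoms are joined, not only to how many there are. Nothing available here bears on why this happens.

Open, as far as these compounds go, is how a cyclopropyl group or a longer chain such as n-pentyl would fare on this nitrogen. Also open, from the compounds shown here alone, is whether the same change would give a step of similar size on the core of compound 3.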